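The source may report more compounds than this note shows. Statements on the series, on what has been measured and on what is new or still open speak of the compounds shown alone.

Measured compounds in an assay on cells for inhibition of Pendrin (Mus musculus), read by fluorescence, with a stated time of 10 min; on this read-out higher numbers stand for weaker inhibition and lower numbers for stronger inhibition:

Compound 1 `Cn1nc(C(=O)O)c2c1CCN(C(=O)Nc1ccc(Cl)cc1)C2`: > 10000 nM
Compound 2 `Cn1nc(COc2cc(F)cc(F)c2)c2c1CCN(C(=O)NC(=O)c1ccccc1)C2`: > 10000 nM
Compound 3 `CC(C)NC(=O)N1CCc2c(c(COc3cc(F)cc(F)c3)nn2C)C1`: > 10000 nM

Each of these three values is a limit of this assay and not a number, as the limit of > 10000 nM in this assay, at which 3 of the 3 values shown sit, records. Compound 3 therefore stands at the limit, as do the other two, and the only step shown, a step that the two limits leave unreadable from compound 2 to compound 3, has no readable size. Compound 4 `Cn1nc(COc2cc(F)cc(F)c2)c2c1CCN(C(=S)NC1CCCCC1)C2` carries a group of 9 heavy atoms (7 carbon, 1 nitrogen, 1 sulfur; one six-membered non-aromatic ring of carbon only) in place of a group of 6 heavy atoms (4 carbon, 1 nitrogen, 1 oxygen; no ring), on an amine nitrogen in a ring. Within the data shown here, no measured step bears on this exchange, and none of the values shown gives a number to build from. Compound 4 is therefore expected most likely to return a limit again, with an estimate of 10000 nM (range 3000 nM to 30000 nM). The expected step from compound 3 is then a number no higher from compound 3 to compound 4 (the limit leaves the size open), which is no readable step beyond the scatter.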

Compound 4, half-maximal inhibitory concentration: > 10000 nM
Compound 4 was reported as a limit; the forecaster's own chance of this, stated with the estimate: 70%; the middle value sits exactly at the limit.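

No new step can be read between compound 3 and compound 4, since both values are limits: the limit of > 10000 nM in this assay, at which 4 of the 4 values shown sit.

The compounds shown leave open which change to the shared core, if any, gives a number in this assay.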